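This account rests on a few compounds, and the source may have more. Where it says the series, first, only, none or still open, it means among the compounds named here.

Compound 1, `COC(=O)c1ccc2c(ccn2-c2ccc(NC(=O)c3ccc(Cl)c(C(F)(F)F)c3)cc2)n1`, gives 2900 nM in an ADME assay on HS27 cells (Homo sapiens) for cytotoxicity, read by MTT assay; a lower number here means a stronger inhibitor, a higher number a weaker inhibitor. Compound 3, `COC(=O)c1ccc2c(ccn2-c2ccc(NC(=O)Nc3ccc(Cl)c(Cl)c3)cc2)n1`, gives 2800 nM in this assay. Compound 2, `COC(=O)c1ccc2c(ccn2-c2ccc(NC(=O)Nc3cccc(Cl)c3Cl)cc2)n1`, reaches only the limit of this assay, > 10000 nM, and so has no number.

Of the two numbers, compound 1 has the higher one, but compound 3 sits within the usual scatter of it: a 1.0-fold lower number from compound 1 to compound 3 (0.02 log units; within the scatter). Compound 4, `NC(=O)c1ccc2c(ccn2-c2ccc(NC(=O)c3ccc(Cl)c(C(F)(F)F)c3)cc2)n1`, differs from compound 1 at the other end of the molecule: amino in place of methoxy on a carbonyl carbon. The measured steps, an at least 3.4-fold higher number from compound 1 to compound 2 (0.53 log units; beyond the scatter) and an at least 3.5-fold lower number from compound 2 to compound 3 (0.55 log units; beyond the scatter), change only the chlorinated phenyl group on the amide or urea side, so none of them bears on the ester-to-amide change. No step beyond the scatter is therefore expected; the estimate for compound 4 is 3000 nM, in a range from 1200 nM to 8000 nM, which would mean a 1.0-fold higher number from compound 1 to compound 4 (0.01 log units; within the scatter).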

Compound 4, half-maximal inhibitory concentration: > 10000 nM
Compound 4 gave a limit, no number; the forecaster's own chance of this, stated with the estimate: 20%; middle value at least 3.3-fold (0.52 log units) away from the limit.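

In this assay, within the data shown here, amino in place of methoxy on a carbonyl carbon gives an at least 3.4-fold higher number from compound 1 to compound 4 (0.53 log units; beyond the scatter) and so shows that this end of the molecule, untouched by the earlier steps, can also shift the reading. Compound 4 gives only a limit of the assay, not a number. As far as these compounds go, the full size of the step stays unknown because the reading stops at that limit: the limit of > 10000 nM in this assay, at which 2 of the 4 values shown sit.

Still open, from the compounds shown here alone, is how a carboxylic acid or a dimethylamide on this carbonyl would read. Also open, going by these compounds, is whether amino in place of methoxy would shift compound 3 in the same way.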